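Nitro in place of methyl: notes on compound 4

This account rests on a few compounds, and the source may have more. Where it says the series, first, only, none or still open, it means among the compounds named here.

Measured in a functional assay on MCF7 cells (Homo sapiens) for cytotoxicity, read by MTT assay, with a stated time of 48 h; a higher number here means a weaker inhibitor, a lower number a stronger inhibitor:
compound 1 `CCn1c(/C=C2/C(=O)Nc3ccc(C)cc32)nc2ccccc21`: > 50000 nM, a limit of the assay
compound 2 `Cn1c(/C=C2/C(=O)Nc3ccc(Br)cc32)nc2ccccc21`: > 50000 nM, a limit of the assay
compound 3 `CC(C)n1c(/C=C2/C(=O)Nc3ccc(F)cc32)nc2ccccc21`: 29000 nM

Compound 1 stands at a limit of this assay rather than at a number; (the limit of > 50000 nM in this assay, at which 2 of the 3 values shown sit). Among the compounds with values here, compound 3 is the one member of the set with a numerical value, and that value is a weak one. No pair among these three differs in only one place, so no measured step is available, and no cause for the spread can be given.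

Compound 4 `CCn1c(/C=C2/C(=O)Nc3ccc([N+](=O)[O-])cc32)nc2ccccc21` differs from compound 1 by nitro in place of methyl on an aromatic carbon. Since compound 1 sits at a limit, the step cannot be read against a number. The change in this assay is expected to be small, at most a modest gain in potency that may not exceed the scatter. The value of compound 4 is estimated at 40000 nM, with a range from 15000 nM to 100000 nM. This amounts to an expected step of an at least 1.2-fold lower number from compound 1 to compound 4 (0.09 log units; that floor lies within the scatter). A result reported only as a limit remains a real possibility.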

Compound 4, half-maximal inhibitory concentration: > 50000 nM
Compound 4 gave a limit, no number; the forecaster's own chance of this, stated with the estimate: 50%; middle value at least 1.2-fold (0.09 log units) away from the limit.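

Compound 1 and compound 4 both stand at a limit in this assay, so no step can be read for nitro in place of methyl on an aromatic carbon: the limit of > 50000 nM in this assay, at which 3 of the 4 values shown sit.

The compounds shown leave open whether this replacement changes the value at all.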